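Cytotoxicity in Vero Cells: From Compound 3 to Compound 4

The source may report more compounds than this note shows. Statements on the series, on what has been measured and on what is new or still open speak of the compounds shown alone.

Compound 1 `C[C@]1(CN2CCc3nc(-c4ccc(F)cc4)nnc3C2)Cn2cc([N+](=O)[O-])nc2O1` — in an ADME assay on Vero cells (Chlorocebus sabaeus) for cytotoxicity, read by MTT assay, with a stated time of 72 h (on this read-out higher numbers stand for lower toxicity in this test and lower numbers for higher toxicity in this test), compound 1 shows "not determined" (no result reported).
Compound 2 `C[C@]1(CN2CCc3nc(-c4ccc(F)cc4)sc3C2)Cn2cc([N+](=O)[O-])nc2O1` — in this assay compound 2 gives > 32 ug/mL, which is a limit of the assay and not a number.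
Compound 3 `C[C@]1(CN2CCc3nc(N4CCCCC4)ccc3C2)Cn2cc([N+](=O)[O-])nc2O1` — in this assay compound 3 shows "not determined" (no result reported).

Compound 3 therefore stands without a single number in this assay; of the three entries shown, one is a limit and one more carries no number at all. The only concrete point in this series is the limit of compound 2, noted as the limit of > 32 ug/mL in this assay, at which 1 of the 3 values shown sits.

Compound 4 `C[C@]1(CN2CCc3nc(-c4ccc(Cl)c(F)c4)ccc3C2)Cn2cc([N+](=O)[O-])nc2O1` differs from compound 3 in one place: 4-chloro-3-fluorophenyl in place of piperidin-1-yl on an aromatic carbon. Among the measured compounds shown here, no measured step joins the two compounds, so nothing here shows how large a change to expect. With compound 3 unmeasured and compound 2 sitting at a limit in this assay, the expected step for compound 4 is none beyond the scatter, with no direction to be read from the data. For compound 4 the estimated half-maximal cytotoxic concentration in this assay is 40 ug/mL, with a range from 16 ug/mL to 100 ug/mL, and a limit rather than a number is the likelier report.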

Compound 4, half-maximal cytotoxic concentration: > 32 ug/mL
Compound 4 was reported as a limit (the forecaster's own chance of this, stated with the estimate: 70%); the middle value lies beyond the limit too.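

Among the compounds shown here, neither compound 3 nor compound 4 has a single number in this assay, so no step between them can be read. The compounds shown leave open how the half-maximal cytotoxic concentration responds when 4-chloro-3-fluorophenyl replaces piperidin-1-yl, and how far compound 2 and compound 4 lie past their shared reported value: the limit of > 32 ug/mL in this assay, at which 2 of the 4 values shown sit.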